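The compounds below may be only part of what the source reports. "The series", "measured", "known", "first", "only" and "open" are said of these compounds alone.

Measured compounds:
Compound 1, `COc1cc(-c2cc(/C=C/C(=O)c3ccc(Cl)c(Cl)c3)[nH]n2)cc(OC)c1OC`: 89%
Compound 2, `COc1ccc(-c2cc(/C=C/C(=O)c3ccc(N)cc3)[nH]n2)cc1OC`: 84%
Compound 3, `COc1ccc(-c2cc(/C=C/C(=O)c3cc(OC)c(OC)c(OC)c3)[nH]n2)cc1OC`: 96%

These three compounds share a core and were tested in a functional assay on BT-549 cells (Homo sapiens) for cytotoxicity, read by sulforhodamine B assay, with a stated time of 48 h, tested at 0.01 uM; a higher number here means a weaker effect of the compound at the concentration tested, a lower number a stronger effect. The number for compound 1 differs from that of compound 2 and from that of compound 3 by less than the usual scatter of repeated measurements, so the three cannot be told apart on these numbers: each leaves most of the cells growing at this low concentration.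

Compound 4, `COc1ccc(C(=O)/C=C/c2cc(-c3cc(OC)c(OC)c(OC)c3)n[nH]2)cc1OC`, has not yet been measured. It differs from compound 1 in one place:
3,4-dimethoxyphenyl in place of 3,4-dichlorophenyl on a carbonyl carbon
Compound 3 already carries methoxy-bearing rings on both sides of the core and gives 96%, a number within the scatter of compound 1. No step beyond the scatter is therefore expected in this assay for the move a number 2 percentage points higher from compound 1 to compound 4 (within the scatter), in neither direction. Compound 4 is estimated to give about 91%, with a range from 80% to 100%.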

Compound 4, a percentage reported as activity, at one concentration (the size of the read-out at that concentration, not a potency): 95%
Beside the measured number, compound 4's estimate is 4 percentage points below it; low and high end bracket the measured number.
By their numbers in this assay, from the lowest: compounds 2, 1, 4 and 3 (each within the scatter of the next, the first and the last beyond it).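

For the compounds shown here, this is the first pair in the set that differs in one place only, so the group on the carbonyl carbon can be judged on its own. In this assay, 3,4-dimethoxyphenyl in place of 3,4-dichlorophenyl gives a number 6 percentage points higher from compound 1 to compound 4 (within the scatter), so the two compounds cannot be told apart at this single low concentration, even though the entering group carries oxygen atoms where the leaving group carries chlorine. Nothing at hand offers an explanation for this result or links it to a property of either group.

On these data alone, it remains open whether a carboxylic acid or a dimethylamino group on this ring would shift the number beyond the scatter. As far as these compounds go, it is also open whether compound 1 and compound 4 would still read alike at a higher concentration.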